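The source may report more compounds than this note shows. Statements on the series, on what has been measured and on what is new or still open speak of the compounds shown alone.

Compound 1, `CCc1cc(Br)c(S(C)(=O)=O)cc1C(=O)N=C(N)N`, gives 41 nM in a functional assay for inhibition of sodium/hydrogen exchanger (Oryctolagus cuniculus); a lower number here means a stronger inhibitor, a higher number a weaker inhibitor.
Compound 2, `Cc1c(C(=O)N=C(N)N)cc(S(C)(=O)=O)c(Cl)c1[N+](=O)[O-]`, gives 44 nM in this assay.
Compound 3, `CCCc1cc(C)c(C(=O)N=C(N)N)cc1S(C)(=O)=O`, gives 5.7 nM in this assay.

All three compounds share a core that carries an acylguanidine and a methylsulfonyl group and differ in the other substituents on the ring. Compound 3 has the lowest number of the three in this assay, and both gaps, to compound 1 and to compound 2, lie beyond the usual scatter, so compound 3 is the strongest inhibitor here.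

Compound 4, `Cc1cc(Sc2ccc(Cl)cc2)c(S(C)(=O)=O)cc1C(=O)N=C(N)N`, has not yet been measured. It differs from compound 3 in one place: (4-chlorophenyl)sulfanyl in place of propyl on an aromatic carbon. The entering group is considerably larger than the one it replaces and brings an aromatic ring of its own, so the change is not a small one. Among the measured compounds shown here, no pair of measured compounds here shows the effect of such a change. Compounds 1 to 3 differ from one another in several substituents at once, and none of those differences is this one. On that thin basis, a modest loss of potency is expected, with a step of a 2.6-fold higher number from compound 3 to compound 4 (0.42 log units; beyond the scatter) that could plausibly be within the scatter. Compound 4 is therefore estimated at 15 nM, in a range from 4 nM to 60 nM.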

Compound 4, half-maximal inhibitory concentration: 19 nM
For compound 4 the middle estimate is 1.3-fold (0.10 log units) below the measured one, and the stated range covers the measured number.
By their numbers in this assay, from the lowest: compound 3; then compound 4; then compounds 1 and 2 (each within the scatter of the next).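

In this assay, replacing propyl with (4-chlorophenyl)sulfanyl on the aromatic carbon ortho to the methylsulfonyl group gives a 3.3-fold higher number from compound 3 to compound 4 (0.52 log units; beyond the scatter), a modest step that lies beyond the usual scatter. Among the compounds shown here, this is the first single-place comparison, and it shows that this position can carry a much larger group, with 8 heavy atoms and an aromatic ring of its own in place of a chain of 3 carbons, at a modest loss of potency: compound 4 still gives 19 nM. No measurement here explains why the step has this size.

The change alters several things at once, adding a sulfur atom, an aromatic ring and a chlorine, so this one step cannot show which of them accounts for the loss, and a plain phenylsulfanyl group without the chlorine, or a phenoxy group with oxygen in place of sulfur, would help to separate them. For the compounds shown here, also open is how a small amine or a longer alkyl chain would fare at this position, since propyl and (4-chlorophenyl)sulfanyl are the only two groups compared there.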